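This account rests on a few compounds, and the source may have more. Where it says the series, first, only, none or still open, it means among the compounds named here.

Going by the values given here, in an assay for inhibition of beta-glucuronidase (Bos taurus), read by spectrophotometry, with a stated time of 30 min (on this read-out lower numbers stand for stronger inhibition and higher numbers for weaker inhibition), compound 3 `CCC1NC(=O)NC(C)=C1C(=O)OC` gives 52200 nM, the second highest of the three numbers measured so far. Compound 1 `COC(=O)C1=C(C)NC(=O)NC1c1ccccc1OC` gives 59200 nM, which lies within the scatter of the number for compound 3, while compound 2 `COC(=O)C1=C(C)NC(=O)NC1c1cccc(O)c1` gives 15200 nM, a lower number that stands beyond the scatter. Compound 4 `COC(=O)C1=C(C)NC(=O)NC1c1cccs1` has not yet been measured. It differs from compound 3 in one place: thiophen-2-yl in place of ethyl on a saturated ring carbon. Compound 1 and compound 2, which carry an aromatic ring where compound 3 carries ethyl, give numbers above and below that of compound 3, so the change offers no clear direction. A modest step towards a lower number, or none beyond the scatter, is expected, written as a 1.6-fold lower number from compound 3 to compound 4 (0.21 log units; within the scatter). For compound 4 the estimated value in this assay is 32000 nM, with a range from 9000 nM to 110000 nM.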

Compound 4, half-maximal inhibitory concentration: 18200 nM
Estimate against measurement, compound 4: 1.8-fold (0.25 log units) above; measured number inside the range.
By their numbers in this assay, from the lowest: compounds 2 and 4 (each within the scatter of the next); then compounds 3 and 1 (each within the scatter of the next).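

In this assay, thiophen-2-yl in place of ethyl on the saturated ring carbon gives a 2.9-fold lower number from compound 3 to compound 4 (0.46 log units; beyond the scatter). This is the first single change shown at this position, and it shows that the number responds to the group there by more than the scatter. Nothing given here explains the step. Going by these compounds, whether the lower number needs the sulfur or only an aromatic ring remains open, and furan-2-yl or unsubstituted phenyl at this carbon would test that. How a longer chain or an amine there would read is also unknown.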